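Adding a Fluoro Atom: Expected Effect on Receptor Agonism

The source may report more compounds than this note shows. Statements on the series, on what has been measured and on what is new or still open speak of the compounds shown alone.

Compound 1, `CON(C)C(=O)c1ccc(-c2csc3c(OC4CCN(C(=O)OC(C)(C)C)CC4)ncnc23)cc1F`: 57 nM
Compound 2, `CCc1cnc(N2CCC(Oc3ncnc4c(-c5ccc(C(=O)N(C)OC)cc5)csc34)CC2)nc1`: 199 nM

Both were tested in a functional assay on cells for agonist activity at Glucose-dependent insulinotropic receptor (Homo sapiens), read by a luciferase reporter, with a stated time of 6 h; on this read-out lower numbers stand for an effect already at smaller amounts and higher numbers for an effect only at larger amounts of compound. Compound 1 gives 57 nM, and compound 2 gives 199 nM; compound 2 thus stands at the higher of the two numbers, and its gap from compound 1 lies beyond the usual scatter. Compound 3, `CCc1cnc(N2CCC(Oc3ncnc4c(-c5ccc(C(=O)N(C)OC)c(F)c5)csc34)CC2)nc1`, is compound 2 with one change: fluoro in place of hydrogen on an aromatic carbon. Compound 1 already carries such a fluoro, but it also differs from compound 2 elsewhere, so the fluoro alone cannot be read from these numbers. The expected step is a 1.7-fold lower number from compound 2 to compound 3 (0.22 log units; within the scatter), a small move toward a lower number, hardly larger than the scatter. Compound 3 is estimated at 120 nM, within 50 nM to 300 nM.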

Compound 3, half-maximal effective concentration: 105 nM
Compound 3: middle estimate off by 1.1-fold (0.06 log units), on the high side; the measured number falls inside the stated range.
By their numbers in this assay, from the lowest: compounds 1, 3 and 2 (each within the scatter of the next, the first and the last beyond it).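

In this assay fluoro in place of hydrogen on the aromatic carbon ortho to the methoxy(methyl)carbamoyl group gives a 1.9-fold lower number from compound 2 to compound 3 (0.28 log units; within the scatter) and so cannot be told apart from repeat-measurement noise at this position. With that fluoro present, 5-ethylpyrimidin-2-yl in place of tert-butoxycarbonyl on the amine nitrogen in a ring gives a 1.8-fold higher number from compound 1 to compound 3 (0.27 log units; within the scatter) and likewise stays unresolved. No independent measurement here explains either step. Open, as far as these compounds go, is whether chloro, methyl or methoxy on this same aromatic carbon would give a step beyond the scatter.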